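The compounds below may be only part of what the source reports. "The series", "measured", "known", "first", "only" and "open" are said of these compounds alone.

In a functional assay on KB cells (Homo sapiens) for cytotoxicity (a lower number here means that less compound is needed, a higher number that more compound is needed for the effect), two compounds sharing one core have been measured so far. Compound 1 `CCOc1cc(-c2ccccc2)nc2ccccc12` gives 6.7 ug/mL, and compound 2 `CCCCOc1cc(-c2ccccc2)nc2ccccc12` gives 3.8 ug/mL. Among the compounds with values here, compound 2 therefore stands level with compound 1, its only neighbour on this scale: the gap, a 1.8-fold lower number from compound 1 to compound 2 (0.25 log units; within the scatter), does not separate them. The next compound, compound 3 `CS(=O)(=O)Oc1cc(-c2ccccc2)nc2ccccc12`, keeps the core but changes what the oxygen on the aromatic ring carries: methylsulfonyl in place of butyl on an oxygen on an aromatic ring. In words, methylsulfonyl takes the place of butyl, turning butoxy into (methylsulfonyl)oxy. Within the data shown here, only one measured step bears on this change, and only loosely. Among the measured compounds shown here, that step, a 1.8-fold lower number from compound 1 to compound 2 (0.25 log units; within the scatter), adds ethyl on the saturated chain, and no measured compound carries methylsulfonyl. The data thus show tolerance for a change of chain but say nothing direct about this replacement, and they favour neither direction. No shift beyond the scatter is expected in this assay, and the expected step is a 1.3-fold higher number from compound 2 to compound 3 (0.12 log units; within the scatter). For compound 3 the estimated value is 5 ug/mL, with an expected range from 1.5 ug/mL to 16 ug/mL.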

Compound 3, half-maximal effective concentration: 2.8 ug/mL
Beside the measured number, compound 3's estimate is 1.8-fold (0.25 log units) above it; the range from low to high includes it.
By their numbers in this assay, from the lowest: compounds 3, 2 and 1 (each within the scatter of the next, the first and the last beyond it).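

In this assay, replacing butyl with methylsulfonyl on the oxygen leaves compound 3 level with compound 2 (a 1.4-fold lower number from compound 2 to compound 3 (0.13 log units; within the scatter)), so this position accepts more than a plain carbon chain: a group with sulfur, double bonds outside aromatic rings and hydrogen-bond acceptors fits here without a shift beyond the scatter. Measured against compound 1, the same group gives the first separation in the series, though only a modest one (a 2.4-fold lower number from compound 1 to compound 3 (0.38 log units; beyond the scatter)), whereas the earlier pair of ethyl and butyl ethers showed no gap beyond the scatter. No available evidence explains why the number stays in this range with methylsulfonyl on the oxygen.

The compounds shown leave open whether an amine or a carboxylic acid carried on this oxygen, a chain longer than butyl, or a free hydroxyl in place of the whole substituent would keep the number in this range. They also leave open whether a larger sulfonyl, such as phenylsulfonyl, would behave like methylsulfonyl.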